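The source may report more compounds than this note shows. Statements on the series, on what has been measured and on what is new or still open speak of the compounds shown alone.

In a physicochemical assay for solubility, measured as kinetic solubility, at pH 7.4, tested at 200 uM (a higher number here means a more soluble compound, a lower number a less soluble compound), compound 1 `Cc1c(-c2cncc(-c3ccc(OC(F)(F)F)cc3)c2)[nH]c2ccccc2c1=O` gives 3600 nM. Within the data shown here, this is the lower of the two numbers available so far. The other comes from compound 2 `COc1ccc2c(=O)c(C)c(-c3cncc(-c4ccc(Cl)c(Cl)c4)c3)[nH]c2c1`, which gives 14000 nM, and the gap between them lies beyond the usual scatter of repeat measurements.

The next compound to test is compound 3 `COc1ccc2c(=O)c(C)c(-c3cncc(-c4ccc(OC(F)(F)F)cc4)c3)[nH]c2c1`. It is compound 1 with methoxy in place of hydrogen on an aromatic carbon. That carbon sits on a six-membered aromatic ring of carbon only, part of a fused or bridged system of two rings.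

Among the measured compounds shown here, no measured pair of compounds shows this change on its own. Compound 3 differs in a second place from compound 2, which carries a methoxy too and gives 14000 nM, so that number says little about the methoxy alone. With so little to go on, the safest expectation is a small shift at most, perhaps slightly upward. The expected step, a 1.3-fold higher number from compound 1 to compound 3 (0.10 log units; within the scatter), stays within the scatter. For compound 3 the estimated value is 4500 nM, with an expected range from 1500 nM to 14000 nM.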

Compound 3, solubility: < 1000 nM
Compound 3 was reported as a limit; the forecaster's own chance of this, stated with the estimate: 10%; middle value at least 4.5-fold (0.65 log units) from the limit.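

In this assay compound 3 gives < 1000 nM, and this value is a limit of the assay, not an exact number. Placing methoxy in place of hydrogen on this aromatic carbon, which is meta to a fused ring and para to a fused ring on the six-membered aromatic ring of carbon only, gives the first single change that can be read in this series: an at least 3.6-fold lower number from compound 1 to compound 3 (0.55 log units; beyond the scatter). So this small addition of 2 heavy atoms at this position is enough to move the read-out clearly downward, though the full size of the step stays hidden, and the reading ends at the edge of what the assay reports: the limit of < 1000 nM in this assay, at which 1 of the 3 values shown sits.

Compound 2 also carries the methoxy and gives 14000 nM, but no compound shown is its partner without the methoxy, so whether the same downward step holds alongside its other substituents remains open. From the compounds shown here alone, it is also open whether a different group on this same carbon, such as an amine or a carboxylic acid, would give a lower or a higher number than hydrogen or methoxy.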